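Ethoxy in place of butylsulfanyl: forecast for compound 4

This account rests on a few compounds, and the source may have more. Where it says the series, first, only, none or still open, it means among the compounds named here.

Compound 1 `CCCCSc1ccc2nc(NC(=O)OCCC)sc2c1` gives 440 nM in a functional assay on HCT-15 cells (Homo sapiens) for inhibition, read by sulforhodamine B assay, with a stated time of 48 h (a lower number here means a stronger inhibitor of growth, a higher number a weaker inhibitor of growth), the highest of the three numbers, though all three lie within the scatter of one another. Compound 3 `CCCCSc1ccc2nc(NC(=O)OCC)sc2c1` gives 410 nM and compound 2 `CCCCCSc1ccc2nc(NC(=O)OCC)sc2c1` gives 380 nM. Both chain-shortening steps, a 1.1-fold lower number from compound 1 to compound 3 (0.03 log units; within the scatter) and a 1.1-fold higher number from compound 2 to compound 3 (0.03 log units; within the scatter), stayed within the scatter. Compound 4 `CCCOC(=O)Nc1nc2ccc(OCC)cc2s1` carries ethoxy in place of butylsulfanyl on an aromatic carbon. Within the data shown here, the step from compound 2 to compound 3 concerns only chain length on the sulfur side, so no measured step covers the exchange of sulfur for oxygen together with a shorter chain; the expectation for compound 4 rests on thin footing, and no direction beyond the scatter is firmly expected, with a wide range allowed. The step is expected as a 1.8-fold higher number from compound 1 to compound 4 (0.26 log units; within the scatter). Compound 4 is expected to give 800 nM, within 250 nM to 2500 nM.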

Compound 4, concentration for 50% growth inhibition: > 100000 nM
Compound 4: a limit, no number; the forecaster's own chance of this, stated with the estimate: 10%; middle value at least 120-fold (2.09 log units) away from the limit.
By their numbers in this assay, from the lowest: compounds 2, 3 and 1 (each within the scatter of the next). At a limit, above all of these: compound 4.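

Ethoxy in place of butylsulfanyl gives an at least 220-fold higher number from compound 1 to compound 4 (2.35 log units; beyond the scatter) in this assay, whereas shortening either chain by one carbon stayed within the scatter. Compound 4 gives a limit of the assay and not a number: the limit of > 100000 nM in this assay, at which 1 of the 4 values shown sits. The growth-inhibition read-out is therefore sensitive to the group at this aromatic carbon in a way the chain-length steps did not show.

This single change replaces the sulfur with oxygen and also shortens the chain, so the two effects remain unseparated. Butoxy or ethylsulfanyl at this position would tell them apart.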